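Working notes: replacing the 4-hydroxyphenyl group of compound 2

The compounds below may be only part of what the source reports. "The series", "measured", "known", "first", "only" and "open" are said of these compounds alone.

- compound 1 `O=C(Cc1csc2nc(-c3ccc(Br)cc3)cn12)N/N=C/c1ccccc1`: 5620 nM
- compound 2 `O=C(Cc1csc2nc(-c3ccc(Br)cc3)cn12)N/N=C/c1ccc(O)cc1`: 7080 nM

Both values come from a functional assay on SK-MEL-5 cells (Homo sapiens) for inhibition, read by sulforhodamine B assay, with a stated time of 48 h; a higher number here means a weaker inhibitor of growth, a lower number a stronger inhibitor of growth. Going by the values given here, compound 2 stands within the scatter of compound 1, the only other measured compound, so the two cannot be ranked.

The next compound is compound 3 `COc1cccc(OC)c1/C=N/NC(=O)Cc1csc2nc(-c3ccc(Br)cc3)cn12`, not yet measured. The change is 2,6-dimethoxyphenyl in place of 4-hydroxyphenyl on a carbon with a double bond to nitrogen.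

Among the compounds with values here, one measured step bears on this part of the structure, with hydroxy in place of hydrogen on an aromatic carbon: a 1.3-fold higher number from compound 1 to compound 2 (0.10 log units; within the scatter). Within the data shown here, no measured compound carries a methoxy group, so this support is thin and the range must stay wide. Resting on that single step of a 1.3-fold higher number from compound 1 to compound 2 (0.10 log units; within the scatter), no step beyond the scatter is expected in this assay, and no direction can be given. The estimated step is a 1.2-fold lower number from compound 2 to compound 3 (0.07 log units; within the scatter). For compound 3 the estimated value is 6000 nM, with an expected range from 2000 nM to 15000 nM.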

Compound 3, concentration for 50% growth inhibition: 8910 nM
Compound 3: the middle estimate sits 1.5-fold (0.17 log units) below what was measured; the range from low to high includes it.
By their numbers in this assay, from the lowest: compounds 1, 2 and 3 (each within the scatter of the next).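

In this assay the exchange of 4-hydroxyphenyl for 2,6-dimethoxyphenyl on a carbon with a double bond to nitrogen gives a 1.3-fold higher number from compound 2 to compound 3 (0.10 log units; within the scatter) and the exchange of phenyl for the same group gives a 1.6-fold higher number from compound 1 to compound 3 (0.20 log units; within the scatter) as the second reading at this position. The position thus takes a group of 10 heavy atoms with 0 hydrogen-bond donors in place of one of 7 heavy atoms with 1 hydrogen-bond donor, with both steps inside the scatter, so the hydroxy group of compound 2 is not required for a reading in this range, and two methoxy groups on the ring are tolerated together. No measured information is available to explain these readings.

From the compounds shown here alone, whether any group at this position can give a step beyond the scatter stays open, for example an amine or a carboxylic acid on the phenyl ring, or a longer chain in place of the ring. Going by these compounds, how a single methoxy group on the ring would read, apart from the pair in compound 3, also stays open.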